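A Straight Chain in Place of a Branched One

This account rests on a few compounds, and the source may have more. Where it says the series, first, only, none or still open, it means among the compounds named here.

Three analogues built on a shared core have been measured in a functional assay on PC-3 cells (Homo sapiens) for inhibition, read by sulforhodamine B assay, with a stated time of 72 h; on this read-out lower numbers stand for stronger inhibition and higher numbers for weaker inhibition. Compound 1 `Nc1sc(-c2ccc(Cl)cc2)c(-c2ccc(Cl)cc2)c1C(=O)NC1CCC(O)CC1` gives 5670 nM in this assay. Compound 2 `CC1CN(C(=O)c2c(N)sc(-c3ccc(Cl)cc3)c2-c2ccc(Cl)cc2)CCN1` gives 7210 nM in this assay, and compound 3 `CC(C)CNC(=O)c1c(N)sc(-c2ccc(Cl)cc2)c1-c1ccc(Cl)cc1` gives 13200 nM in this assay. Compound 3 thus shows the highest number of the three: the step of a 2.3-fold higher number from compound 1 to compound 3 (0.37 log units; beyond the scatter) lies beyond the scatter, whereas a 1.8-fold higher number from compound 2 to compound 3 (0.26 log units; within the scatter) and a 1.3-fold higher number from compound 1 to compound 2 (0.10 log units; within the scatter) do not.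

Compound 4 `CCCCNC(=O)c1c(N)sc(-c2ccc(Cl)cc2)c1-c1ccc(Cl)cc1` has not yet been measured. It differs from compound 3 in one place: propyl in place of isopropyl on a saturated chain carbon bound to an amide-type nitrogen. Within the data shown here, none of the measured steps alters only the shape of a chain on the amide-type nitrogen; a 2.3-fold higher number from compound 1 to compound 3 (0.37 log units; beyond the scatter) exchanges the 4-hydroxycyclohexyl group for the isobutyl chain, and a 1.8-fold higher number from compound 2 to compound 3 (0.26 log units; within the scatter) exchanges the 3-methylpiperazin-1-yl group for isobutylamino, so both speak only loosely to the present change. Among the measured compounds shown here, with no direct precedent among the measured compounds, and the change being small, the step is expected to stay within the scatter in this assay. The estimate for compound 4 is 13000 nM, in the range 6000 nM to 28000 nM. The expected step is a 1.0-fold lower number from compound 3 to compound 4 (0.01 log units; within the scatter), with no direction favoured.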

Compound 4, half-maximal inhibitory concentration: 17800 nM
Compound 4: middle estimate off by 1.4-fold (0.14 log units), on the low side; the range from low to high includes it.
By their numbers in this assay, from the lowest: compounds 1, 2, 3 and 4 (each within the scatter of the next, the first and the last beyond it).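

Among these compounds, this is the first pair in the set that alters only the shape of the chain on the amide-type nitrogen: in this assay, butyl in place of isobutyl gives a 1.3-fold higher number from compound 3 to compound 4 (0.13 log units; within the scatter) and so leaves the number within the scatter. The straight chain still stands apart from both groups containing a ring, with a 3.1-fold higher number from compound 1 to compound 4 (0.50 log units; beyond the scatter) for butyl in place of 4-hydroxycyclohexyl and a 2.5-fold higher number from compound 2 to compound 4 (0.39 log units; beyond the scatter) for butylamino in place of 3-methylpiperazin-1-yl, each beyond the scatter, whereas a 1.8-fold higher number from compound 2 to compound 3 (0.26 log units; within the scatter) for the branched chain was within it. No measurement given here accounts for any of these steps.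

The compounds shown leave open whether a longer chain such as hexyl, or a butyl chain ending in an amine or a carboxylic acid, would carry the number in this assay beyond the scatter from compound 4. On these data alone, all four compounds also share one core, so how these amide groups would rank on any other core remains unknown.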